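Shifting a Methyl Group on a Non-Toxic Compound

The compounds below may be only part of what the source reports. "The series", "measured", "known", "first", "only" and "open" are said of these compounds alone.

Compound 1 `CC(C)(O)c1cn(CC(=O)NCc2ccccc2)nn1`: 1600 uM
Compound 2 `O=C(Cn1cc(C(=O)O)nn1)NCc1ccccc1`: "non-toxic" (no number reported)
Compound 3 `Cc1ccc(-c2cn(CC(=O)NCc3ccccc3)nn2)cc1`: "non-toxic" (no number reported)

In an ADME assay on cells (spleen, Mus musculus, strain C57BL/6) for inhibition, read by flow cytometry and propidium iodide staining, with a stated time of 24 h, at 37 degrees C (a higher number here means that more compound is needed for the effect, a lower number that less compound is needed), only compound 1 has a number, 1600 uM. Compound 2 is reported only as "non-toxic" (no number reported). Compound 3 also has no single number and is reported as "non-toxic" (no number reported), so it cannot be ranked against compound 1.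

Compound 4 `Cc1ccccc1-c1cn(CC(=O)NCc2ccccc2)nn1` has the same atoms as compound 3, joined differently: 2-methylphenyl in place of 4-methylphenyl on an aromatic carbon. Among the measured compounds shown here, no measured pair shows what such a change does, so no step beyond the scatter is expected in this assay, in either direction. For the measured compounds named here, the estimate leans on the only number available, 1600 uM for compound 1.

Compound 4 is expected at about 1500 uM, with an estimated range of 500 uM to 4000 uM.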

Compound 4, concentration for half-maximal effect: 940 uM
Compound 4: middle estimate off by 1.6-fold (0.20 log units), on the high side; the measured number falls inside the stated range.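

In this assay the swap of 1-hydroxy-1-methylethyl for 2-methylphenyl on this aromatic carbon gives a 1.7-fold lower number from compound 1 to compound 4 (0.23 log units; within the scatter) and so leaves the number within the scatter. Compound 4 gives a methylphenyl compound a number (940 uM), but the step from 4-methylphenyl to 2-methylphenyl cannot be read, since compound 3 has no number. Nothing measured here offers a reason for this result. Going by these compounds, whether an amine or a longer chain at this position would move the number beyond the scatter stays open.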